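The source may hold more compounds than are shown below. What is called first, only, known or untested is meant among the compounds shown, and "the series" means these compounds.

Measured in an ADME assay on MDBK cells (Bos taurus) for cytotoxicity, read by MTT assay, with a stated time of 96 h; on this read-out lower numbers stand for higher toxicity in this test and higher numbers for lower toxicity in this test:
Compound 1 `CN1CCN(/N=N/c2cc(F)ccc2F)CC1`: > 100000 nM
Compound 2 `Cc1c(/N=N/c2cccc(C(F)(F)F)c2)ccc(NC[C@@H]2CCCN3CCCC[C@H]23)c1C`: 52000 nM
Compound 3 `Fc1ccc(/N=N/c2ccc(NC[C@@H]3CCCN4CCCC[C@H]34)c3c2CCCC3)c(F)c1`: 11000 nM

The entry for compound 1 is a limit of the assay and not a number. Of the two actual numbers, the higher belongs to compound 2, and its gap to compound 3 lies beyond the scatter. Compound 4 `Cc1c(/N=N/c2ccccc2)ccc(NC[C@@H]2CCCN3CCCC[C@H]23)c1C` is the next case, with hydrogen in place of trifluoromethyl on an aromatic carbon. For the measured compounds named here, no measured step isolates this change, so no step beyond the scatter is expected in this assay. The expected change is a 1.3-fold lower number from compound 2 to compound 4 (0.11 log units; within the scatter). For compound 4 the estimated value is 40000 nM, with an expected range from 15000 nM to 100000 nM.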

Compound 4, half-maximal cytotoxic concentration: 48000 nM
Beside the measured number, compound 4's estimate is 1.2-fold (0.08 log units) below it, and the stated range covers the measured number.
By their numbers in this assay, from the lowest: compound 3; then compounds 4 and 2 (each within the scatter of the next). At a limit, above all of these: compound 1.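

In this assay, for the compounds shown here, the exchange of trifluoromethyl for hydrogen on this aromatic carbon gives a 1.1-fold lower number from compound 2 to compound 4 (0.03 log units; within the scatter) and is the first change here isolated in one place. Going by these compounds alone, at this position, meta to a large group, 3-(trifluoromethyl)phenyl and phenyl are therefore not told apart in this test, which the earlier compounds could not show. Nothing at hand bears on a cause for this.

Open, from the compounds shown here alone, is whether an amine or a carboxylic acid on this carbon would also stay within the scatter. Also open, going by these compounds, is whether the same exchange reads alike on the core of compound 3.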